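This account rests on a few compounds, and the source may have more. Where it says the series, first, only, none or still open, it means among the compounds named here.

In a functional assay on DU-145 cells (Homo sapiens) for inhibition, read by trypan blue exclusion, with a stated time of 96 h (a lower number here means a stronger inhibitor of growth, a higher number a weaker inhibitor of growth), compound 1 `Cc1ccc(CS/C(=C/c2ccc(O)cc2)C(=O)c2ccc(Cl)cc2)cc1` gives 10000 nM. Compound 2 `Cc1ccc(S(=O)(=O)/C(=C/c2sccc2C)C(=O)c2ccc(Cl)cc2)cc1` gives 10000 nM, which leaves compound 1 level with it and gives neither a claim to the better result. Compound 3 `Cc1ccc(CS/C(=C/c2ccc(F)c(C)c2)C(=O)c2ccc(Cl)cc2)cc1` has not yet been measured. It keeps the core of compound 1 and alters one group, with 4-fluoro-3-methylphenyl in place of 4-hydroxyphenyl on a double-bonded chain carbon bound to a double-bonded chain carbon. The swap removes the only hydrogen-bond donor in the exchanged group, as the count shows.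

Among the compounds with values here, no pair of measured compounds differs in just one place, so the data offer no direct guide to the size of this change. The expectation therefore rests on compound 1 at 10000 nM and remains loose. A modest gain in growth inhibition is expected, with the estimated step being a 2.5-fold lower number from compound 1 to compound 3 (0.40 log units; beyond the scatter), though a result no different from compound 1 would not be surprising. For compound 3 the expected value is 4000 nM, with an estimated range from 500 nM to 15000 nM.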

Compound 3, concentration for 50% growth inhibition: 25000 nM
The estimate for compound 3 lay 6.3-fold (0.80 log units) below the measured number; measured number above the stated range.
By their numbers in this assay, from the lowest: compounds 1 and 2 (each within the scatter of the next); then compound 3.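

In this assay, the exchange of 4-hydroxyphenyl for 4-fluoro-3-methylphenyl on a double-bonded chain carbon bound to a double-bonded chain carbon gives a 2.5-fold higher number from compound 1 to compound 3 (0.40 log units; beyond the scatter) and so weakens growth inhibition modestly. Within the data shown here, this is the first comparison here in which only one place differs, and it shows that the group at this position can alter the read-out, which the level values of the two earlier compounds could not show. Nothing measured on these compounds bears on why the number rises, so the step stands as an observation only.

The compounds shown do not separate the loss of the hydroxyl group from the arrival of the fluorine and the methyl group, since all of these changes come together in compound 3, and a single step gives no trend for this position. On these data alone, it also remains open whether an amine or a carboxylic acid on this phenyl group would hold, improve or further weaken growth inhibition relative to compound 1 at 10000 nM in this assay.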